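The source may hold more compounds than are shown below. What is called first, only, known or untested is meant among the compounds shown, and "the series" means these compounds.

Measured so far:
compound 1, `CCOC(=O)c1sc(NC(=O)Cn2cc(-c3cccs3)nn2)nc1C`: 20 nM
compound 2, `Nc1cccc(-c2cn(CC(=O)Nc3nc4ccccc4s3)nn2)c1`: 1110 nM

Both numbers come from a functional assay on BMDM cells (Mus musculus, strain C57BL/6) for inhibition, with a stated time of 2 days; on this read-out lower numbers stand for stronger inhibition and higher numbers for weaker inhibition. Compound 1 gives 20 nM and holds the lowest of the two numbers shown. Compound 2 gives 1110 nM, a gap to compound 1 that lies well beyond the usual scatter of repeated measurements, so compound 1 is the stronger inhibitor of the pair.

The compound still to be measured is compound 3, `CCOC(=O)c1sc(NC(=O)Cn2cc(-c3ccc(Cl)cc3)nn2)nc1C`. It keeps the whole of compound 1 apart from one ring: 4-chlorophenyl in place of thiophen-2-yl on an aromatic carbon. Going by the values given here, no pair of measured compounds shows a step of this kind, so nothing measured tells how large the change should be. One flat aromatic ring is exchanged for another at the same place, and such a swap is expected to move the number only a little. In this assay the expected step is a 1.8-fold higher number from compound 1 to compound 3 (0.24 log units; within the scatter), which stays within the scatter. Compound 3 is therefore estimated at 35 nM, with a range from 8 nM to 150 nM.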

Compound 3, half-maximal inhibitory concentration: 180 nM
For compound 3 the middle estimate is 5.1-fold (0.71 log units) below the measured one; measured number outside the range, above it.
By their numbers in this assay, from the lowest: compound 1; then compound 3; then compound 2.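

Going by these compounds alone, this is the first direct reading of the group at this place, on an aromatic carbon of the five-membered aromatic ring with 3 nitrogen, and it shows that one aromatic ring cannot simply stand in for another there. In this assay the switch from thiophen-2-yl to 4-chlorophenyl gives a 9.0-fold higher number from compound 1 to compound 3 (0.95 log units; beyond the scatter) while the rest of the molecule stays the same, so the choice of ring at this place matters for inhibition in these cells. The change replaces a five-membered ring holding sulfur with a six-membered ring of carbon carrying chlorine, and no measurement at hand explains why the number rises.

A single step cannot separate the ring size, the sulfur and the chlorine, so it remains open which of them accounts for the difference, and a plain phenyl ring without chlorine or furan-2-yl at the same place would help to tell them apart. From the compounds shown here alone, it also remains open how the number would respond to changes elsewhere on the shared core, such as a carboxylic acid in place of the ethyl ester.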